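The compounds below may be only part of what the source reports. "The series", "measured", "known", "first", "only" and "open" are said of these compounds alone.

In a functional assay on HepG2 cells (Homo sapiens) for cytotoxicity, read by MTT assay, with a stated time of 48 h (a lower number here means a stronger inhibitor, a higher number a weaker inhibitor), compound 1 `NNC(=O)CSc1nnc(-c2ccncc2)o1` gives 3260 nM as its reading, and compound 3 `O=C(CSc1nnc(-c2ccncc2)o1)N/N=C/c1ccc(O)cc1` gives 5510 nM as its reading. Compound 2 `O=C(CSc1nnc(-c2ccncc2)o1)N/N=C/c1ccc([N+](=O)[O-])cc1` stands at 17900 nM as the highest of these three numbers, with compound 3 its nearest neighbour and compound 1 the furthest away. Compound 4 `O=C(CSc1nnc(-c2ccncc2)o1)N/N=C/c1cccc(F)c1` has not yet been measured and departs from compound 2 at one place, 3-fluorophenyl in place of 4-nitrophenyl on a carbon with a double bond to nitrogen and so carries 3-fluorophenyl in place of 4-nitrophenyl on a carbon with a double bond to nitrogen.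

For the measured compounds named here, only one measured step bears on this change, and it also removes the nitro group: a 3.2-fold lower number from compound 2 to compound 3 (0.51 log units; beyond the scatter) came with hydroxy in place of nitro on an aromatic carbon, a modest step but one beyond the scatter. Going by the values given here, no measured compound carries 3-fluorophenyl, so this single step is a weak guide, and the estimate stays wide. Resting on a 3.2-fold lower number from compound 2 to compound 3 (0.51 log units; beyond the scatter) as the only precedent, a modest move to a lower number is expected, somewhat smaller than that step. The expected change is a 2.0-fold lower number from compound 2 to compound 4 (0.30 log units; within the scatter) and may not clear the scatter. In this assay compound 4 is estimated at 9000 nM (expected range 3500 nM to 20000 nM).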

Compound 4, half-maximal inhibitory concentration: 19500 nM
Compound 4: middle estimate off by 2.2-fold (0.34 log units), on the low side, and the stated range covers the measured number.
By their numbers in this assay, from the lowest: compounds 1 and 3 (each within the scatter of the next); then compounds 2 and 4 (each within the scatter of the next).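

In this assay, 3-fluorophenyl in place of 4-nitrophenyl on a carbon with a double bond to nitrogen gives a 1.1-fold higher number from compound 2 to compound 4 (0.04 log units; within the scatter) and so leaves the reading unmoved, which shows that losing the nitro group does not by itself bring the number down. The earlier step from compound 2 to compound 3 could not separate removing the nitro group from adding the hydroxy group, but the new comparison, a 3.5-fold higher number from compound 3 to compound 4 (0.55 log units; beyond the scatter) with 3-fluorophenyl in place of 4-hydroxyphenyl, sets compound 3 apart from both other compounds with an aromatic ring at this place. Nothing shown accounts for why compound 3 differs from compound 2 and compound 4 at this position.

The step from compound 3 to compound 4 changes both the group and its printed ring number, so the compounds shown cannot say which of the two matters. From the compounds shown here alone, it also remains open whether an amine or a carboxylic acid on this aromatic ring would read with compound 3 or with compound 2 and compound 4.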